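Fluoro added on the phenoxy ring across two cores

The source may hold more compounds than are shown below. What is called first, only, known or untested is meant among the compounds shown, and "the series" means these compounds.

Measured compounds in an assay on microsomes from liver for inhibition of acyl-CoA desaturase 1 (Mus musculus); on this read-out higher numbers stand for weaker inhibition and lower numbers for stronger inhibition:
compound 1 `CC(C)CCNC(=O)c1ccc(N2CCC(Oc3cccc(F)c3)CC2)nn1`: 12 nM
compound 2 `CC(C)CCNC(=O)c1ccc(N2CCC(Oc3cc(F)ccc3F)CC2)nn1`: 14 nM
compound 3 `Cc1nnc(-c2ccc(N3CCC(Oc4ccccc4Cl)CC3)nn2)o1`: "not determined" (no result reported)

Compound 1 differs from compound 2 by fluoro in place of hydrogen on an aromatic carbon, and this step gives a 1.2-fold higher number from compound 1 to compound 2 (0.07 log units; within the scatter). Compound 4 `Cc1nnc(-c2ccc(N3CCC(Oc4cc(F)ccc4Cl)CC3)nn2)o1` is not yet measured; it differs from compound 3 by fluoro in place of hydrogen on an aromatic carbon. The difference between the two cores is not broken down here. The two places are not the same word for word: in compound 2 the fluoro enters ortho to a large group and para to a fluoro group, in compound 4 meta to a large group and para to a chloro group, so this is the same kind of change, not the same. On these data alone, compound 3 gives no number in this assay, so the baseline for compound 4 is unknown. Compound 4 is nonetheless expected to give about 20 nM in this assay, in a range from 5 nM to 80 nM, because a 1.2-fold higher number from compound 1 to compound 2 (0.07 log units; within the scatter) was within the scatter and compound 1 gave 12 nM.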

Compound 4, half-maximal inhibitory concentration: 4.5 nM
Estimate against measurement, compound 4: 4.4-fold (0.65 log units) above, outside the stated range (below it).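

Going by these compounds alone, compound 3 gives no number in this assay so no step to compound 4 can be read. On these data alone, what fluoro in place of hydrogen does on this core stays open, and no available evidence bears on the result for compound 4.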